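The source may hold more compounds than are shown below. What is called first, only, known or untested is meant among the compounds shown, and "the series" means these compounds.

Measured in an ADME assay (liver) for metabolic stability, with Liver microsome (Rattus norvegicus) as the target, read by LC-MS, using microsomes, with a stated time of 30 min, tested at 4 uM; a higher number here means that more of the compound is left, a lower number that less of the compound is left:
- compound 1 `Cc1nc(N2CCN(C)CC2)c2nc(-c3ccccc3Cl)n(C3CC3)c2n1`: 44%
- compound 2 `CCN1CCN(c2nc(C)nc3c2nc(-c2ccccc2Cl)n3CC2CCOCC2)CC1`: 80%
- compound 3 `Cc1nc(N2CCN(C)CC2)c2nc(-c3cccc(C(F)(F)F)c3)n(C3CCOCC3)c2n1`: 28%

Compound 3, at 28%, is the lowest of the three. Compound 1 at 44% and compound 2 at 80% both stand higher, each beyond the usual scatter of repeated measurements.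

The next compound is compound 4 `Cc1nc(N2CCN(C)CC2)c2nc(-c3ccccc3C#N)n(C3CCOCC3)c2n1`. It keeps the shared core and the oxan-4-yl group of compound 3, but carries 2-cyanophenyl in place of 3-(trifluoromethyl)phenyl on an aromatic carbon.

Among the measured compounds shown here, no two measured compounds differ in only one place, so the data show no direct step for this kind of swap. Compound 1 at 44% and compound 2 at 80% differ from compound 3 in more than one place, so their higher values offer only a loose hint of upward room. A moderate rise is therefore expected, with the estimated change being a number 14 percentage points higher from compound 3 to compound 4 (beyond the scatter), which would lie only slightly beyond the scatter. For compound 4 the estimate in this assay is 42%, with an expected range of 22% to 62%.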

Compound 4, percent of the compound remaining: 21%
The estimate for compound 4 lay 21 percentage points above the measured number; the measured number lies below the stated range.
By their numbers in this assay, from the lowest: compounds 4 and 3 (each within the scatter of the next); then compound 1; then compound 2.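

In this assay, among the compounds shown here, the swap of 3-(trifluoromethyl)phenyl for 2-cyanophenyl on the aromatic carbon between two ring nitrogen atoms gives the first direct step at this position, reading a number 7 percentage points lower from compound 3 to compound 4 (within the scatter). With the shared core, the methylpiperazine and the oxan-4-yl group held fixed, this change does not separate the two compounds in this read-out. No measurement is at hand that would account for this result.

On these data alone, it remains open whether a phenyl ring carrying an amine or a carboxylic acid at this place would give a step beyond the scatter. Also open, as far as these compounds go, is whether the swap to 2-cyanophenyl would read the same with a group other than oxan-4-yl, such as the cyclopropyl group of compound 1.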